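Furan Ester to Trifluoroethoxymethyl Ether: Expectation at the Limit

This account rests on a few compounds, and the source may have more. Where it says the series, first, only, none or still open, it means among the compounds named here.

Compound 2 `CCc1cccc2c(OC)c(-c3occ(C)c3C(=O)NC)ccc12` was examined in a functional assay on KB cells (Homo sapiens) for cytotoxicity, read by MTT assay, with a stated time of 72 h; a higher number here means that more compound is needed for the effect, a lower number that less compound is needed. In this assay compound 2 gives only the limit > 10 ug/mL. In this assay compound 1 `CCCOC(=O)c1c(C)coc1-c1ccc2c(CC)cccc2c1OC` gives the limit > 10 ug/mL. In this assay compound 3 `CCc1cccc2c(OC)c(-c3occ(C)c3C(=O)On3nnc4ccccc43)ccc12` gives the limit > 10 ug/mL. All three thus sit at the limit of > 10 ug/mL in this assay, at which 3 of the 3 values shown sit. The change from compound 2 to compound 4 `CCc1cccc2c(OC)c(-c3occ(C)c3COCC(F)(F)F)ccc12` is (2,2,2-trifluoroethoxy)methyl in place of methylcarbamoyl on an aromatic carbon. The measured steps touching compound 2, a step that the two limits leave unreadable from compound 1 to compound 2 and a step that the two limits leave unreadable from compound 2 to compound 3, are unreadable, with a limit at each end, and a step that the two limits leave unreadable from compound 1 to compound 3 is unreadable as well. Going by the values given here, no measured step gives a size or direction, so no shift beyond the scatter is expected. Compound 4 is expected near 20 ug/mL, between 6 ug/mL and 70 ug/mL, most likely again a limit. That corresponds to an expected step that the limit leaves unreadable from compound 2 to compound 4.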

Compound 4, concentration for half-maximal effect: 6.6 ug/mL
Estimate against measurement, compound 4: 3.0-fold (0.48 log units) above, within the range that was stated.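

In this assay, going by these compounds alone, the (2,2,2-trifluoroethoxy)methyl group on this aromatic carbon gives compound 4 a readable number, which sets it apart from the earlier compounds: the limit of > 10 ug/mL in this assay, at which 3 of the 4 values shown sit. The change reads as an at least 1.5-fold lower number from compound 2 to compound 4 (0.18 log units; that floor lies within the scatter) and as an at least 1.5-fold lower number from compound 1 to compound 4 (0.18 log units; that floor lies within the scatter) with each size a floor only, as the other end is a limit. The steps among compound 1, compound 2 and compound 3 cannot be read. The compounds shown leave open how a plain ethoxymethyl group, a hydroxymethyl group or a carboxylic acid on this carbon would read.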